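A few compounds are considered here, and "the series" means these few. Any claim that something is new, unique, unknown or untested is made for them only; others in the source may bear on it.

Three compounds have been measured in a functional assay on A549 cells (Homo sapiens) for cytotoxicity, read by MTT assay, with a stated time of 72 h; on this read-out higher numbers stand for weaker inhibition and lower numbers for stronger inhibition:

compound 1, `CN(C)CCn1cnnc1-c1cc(Oc2ccc(NC(=O)N/N=C/c3ccc(Cl)cc3)cc2F)ccn1`, gives 780 nM;
compound 2, `CN(C)CCn1cnnc1-c1cc(Oc2ccc(NC(=O)N/N=C/c3ccc(O)c(Br)c3)cc2F)ccn1`, gives 1370 nM;
compound 3, `Cc1cc(/C=N/NC(=O)Nc2ccc(Oc3ccnc(-c4nncn4CCN(C)C)c3)c(F)c2)cc(C)c1O`, gives 1640 nM.

All three share the same core and differ only in the aryl group attached to the carbon with a double bond to nitrogen. Among them compound 3 gives the highest number: the step of a 2.1-fold higher number from compound 1 to compound 3 (0.32 log units; beyond the scatter) lies beyond the scatter, while the step of a 1.2-fold higher number from compound 2 to compound 3 (0.08 log units; within the scatter) does not, so compound 2 and compound 3 cannot be told apart on these data.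

Compound 4, `CN(C)CCn1cnnc1-c1cc(Oc2ccc(NC(=O)N/N=C/c3ccc(F)cc3)cc2F)ccn1`, has not been measured. It differs from compound 3 as follows: 4-fluorophenyl in place of 4-hydroxy-3,5-dimethylphenyl on a carbon with a double bond to nitrogen. The step that bears most on this change is a 2.1-fold higher number from compound 1 to compound 3 (0.32 log units; beyond the scatter), where the same 4-hydroxy-3,5-dimethylphenyl group entered in place of a halogen-bearing phenyl; the change from compound 3 to compound 4 runs the other way, back to a halogen-bearing phenyl, though with fluorine rather than chlorine. The step of a 1.8-fold higher number from compound 1 to compound 2 (0.24 log units; within the scatter), where a hydroxyl-bearing group also entered, stayed within the scatter.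

On this basis compound 4 is expected to give a modestly lower number than compound 3, close to that of compound 1, a step of a 1.8-fold lower number from compound 3 to compound 4 (0.26 log units; within the scatter). The estimate for compound 4 in this assay is 900 nM, with a range from 400 nM to 2000 nM.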

Compound 4, half-maximal inhibitory concentration: 1790 nM
Beside the measured number, compound 4's estimate is 2.0-fold (0.30 log units) below it, and the stated range covers the measured number.
By their numbers in this assay, from the lowest: compounds 1, 2, 3 and 4 (each within the scatter of the next, the first and the last beyond it).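

In this assay, 4-fluorophenyl in place of 4-hydroxy-3,5-dimethylphenyl gives a 1.1-fold higher number from compound 3 to compound 4 (0.04 log units; within the scatter) and in place of 3-bromo-4-hydroxyphenyl gives a 1.3-fold higher number from compound 2 to compound 4 (0.12 log units; within the scatter), so compound 2, compound 3 and compound 4 cannot be told apart, although 4-fluorophenyl has no hydroxyl. For the compounds shown here, a halogen-bearing phenyl on this carbon therefore does not by itself go with the lowest number: fluoro in place of chloro on an aromatic carbon gives a 2.3-fold higher number from compound 1 to compound 4 (0.36 log units; beyond the scatter), a modest step beyond the scatter, and compound 1 is the only compound here that stands apart from compound 4. No measurement shown here explains this difference between the chloro and fluoro compounds.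

The lower number for a chloro group rests on compound 1 alone, so it remains unclear whether it would hold for a bromo group without the hydroxyl or for a second chloro group on the same ring. On these data alone, it also remains open how this position would respond to a phenyl carrying an amine or a carboxylic acid in place of the halogen.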